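A few compounds are considered here, and "the series" means these few. Any claim that something is new, unique, unknown or untested is made for them only; others in the source may bear on it.

Compound 2 `COc1cccc(-n2cc3nc(-c4ccccc4C)n(CC4CCCN(C(C)C)C4)c(=O)c3n2)c1` gives the lowest of the two numbers measured: in an assay on HEK293 cells for displacement of a labelled ligand from growth hormone secretagogue receptor type 1 (Homo sapiens), with a stated time of 60 min (a higher number here means a weaker inhibitor, a lower number a stronger inhibitor), compound 2 gives 1.8 nM, while compound 1 `Cc1ccccc1-c1nc2cn(-c3cccc(C#N)c3)nc2c(=O)n1CC1CCCN(C(C)C)C1` gives 32 nM. Compound 3 `Cc1ccccc1-c1nc2cn(-c3ccc(Cl)cc3)nc2c(=O)n1CC1CCCN(C(C)C)C1` differs from compound 2 by 4-chlorophenyl in place of 3-methoxyphenyl on an aromatic nitrogen. For the measured compounds named here, one measured step bears on this ring: an 18-fold lower number from compound 1 to compound 2 (1.25 log units; beyond the scatter), showing that what sits on this ring can move the number strongly. Compound 3 carries neither of those groups, so compound 3 is expected to show a step of a 5.6-fold higher number from compound 2 to compound 3 (0.74 log units; beyond the scatter) toward a higher number. Compound 3 is therefore estimated at 10 nM, with a range of 3 nM to 40 nM.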

Compound 3, half-maximal inhibitory concentration in the growth hormone secretagogue receptor type 1 assay: 0.28 nM
For compound 3 the middle estimate is 36-fold (1.55 log units) above the measured one; measured number outside the range, below it.
By their numbers in the growth hormone secretagogue receptor type 1 assay, from the lowest: compound 3; then compound 2; then compound 1.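

In the growth hormone secretagogue receptor type 1 assay, the phenyl ring on the aromatic nitrogen can go lower than either earlier group allowed: 4-chlorophenyl gives a 6.4-fold lower number from compound 2 to compound 3 (0.81 log units; beyond the scatter) and a 110-fold lower number from compound 1 to compound 3 (2.06 log units; beyond the scatter), placing compound 3 lowest of the three. In a physicochemical assay for acid dissociation, compound 2 gives 10 and compound 3 gives 10; the same change gives no change at the digits printed from compound 2 to compound 3 (within the scatter). Nothing shown accounts for the gain in binding.

Compound 3 changes both the substituent and its ring position relative to compound 2, so the two contributions cannot be separated. On these data alone, whether an amine or a carboxylic acid on this phenyl ring would hold such a low number also remains open.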